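This account rests on a few compounds, and the source may have more. Where it says the series, first, only, none or still open, it means among the compounds named here.

Of the compounds shown here, three built on one shared core have been measured in an assay on HEK293 cells for inhibition of Voltage-dependent T-type calcium channel subunit alpha-1G (Homo sapiens), read by patch clamp; a higher number here means a weaker inhibitor, a lower number a stronger inhibitor. Compound 1 `CCCc1nc(-c2ccccc2)c(CNCCCN2CCN(c3ccc(F)cc3)CC2)o1` carries a 4-fluorophenyl on an amine nitrogen in a ring and gives 3210 nM. Compound 2 `CCCc1nc(-c2ccccc2)c(CNCCCN2CCN(c3cccc(C)c3)CC2)o1` carries a 3-methylphenyl there and gives 1190 nM. Compound 3 `CCCc1nc(-c2ccccc2)c(CNCCCN2CCN(c3ccccc3C)CC2)o1` carries a 2-methylphenyl there and gives 8750 nM, the highest of the three numbers: the step is a 2.7-fold higher number from compound 1 to compound 3 (0.44 log units; beyond the scatter) and a 7.4-fold higher number from compound 2 to compound 3 (0.87 log units; beyond the scatter), so compound 3 is the weakest inhibitor of the set in this assay.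

Compound 4 `CCCc1nc(-c2ccccc2)c(CNCCCN2CCN(c3ccc(C)c(C)c3)CC2)o1` has not yet been measured. It differs from compound 3 in one place: 3,4-dimethylphenyl in place of 2-methylphenyl on an amine nitrogen in a ring. The entering group contains the methyl placement of 3-methylphenyl and adds a second methyl. The step that bears most directly on this change is a 7.4-fold higher number from compound 2 to compound 3 (0.87 log units; beyond the scatter), since swapping 3-methylphenyl for 2-methylphenyl raised the number considerably, and restoring the 3-methylphenyl pattern should lower it again. a 2.7-fold lower number from compound 1 to compound 2 (0.43 log units; beyond the scatter) points the same way. Whether the added methyl helps or hurts cannot be told from these compounds; compound 1, which carries 4-fluorophenyl, sits between compound 2 and compound 3. The expected step is therefore a 5.8-fold lower number from compound 3 to compound 4 (0.77 log units; beyond the scatter), downward and beyond the scatter. Compound 4 is estimated at 1500 nM, within a range from 500 nM to 5000 nM.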

Compound 4, half-maximal inhibitory concentration: 3020 nM
Compound 4: the middle estimate sits 2.0-fold (0.30 log units) below what was measured, within the range that was stated.
By their numbers in this assay, from the lowest: compound 2; then compounds 4 and 1 (each within the scatter of the next); then compound 3.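

In this assay, going by these compounds alone, the second methyl settles what the earlier compounds could not: adding it to the 3-methylphenyl group gives a 2.5-fold higher number from compound 2 to compound 4 (0.40 log units; beyond the scatter), so in this one pair the extra methyl weakens inhibition. The change away from 2-methylphenyl still strengthens inhibition, with a 2.9-fold lower number from compound 3 to compound 4 (0.46 log units; beyond the scatter), but the gain is smaller than the one seen between the two single-methyl groups, and the added methyl accounts for the shortfall in these numbers. The 3,4-dimethylphenyl and 4-fluorophenyl groups cannot be told apart here, with a 1.1-fold lower number from compound 1 to compound 4 (0.03 log units; within the scatter) lying within the scatter, so this assay shows that two different groups on the ring nitrogen can give equivalent inhibition.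

Nothing shown here explains why the second methyl weakens inhibition or why the methyl placement matters. The compounds also leave open whether 4-methylphenyl alone would match 4-fluorophenyl or 3,4-dimethylphenyl, and whether a larger group such as 3-chlorophenyl or 3-methoxyphenyl would keep or improve on the inhibition of the 3-methylphenyl compound.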